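Pyridin-2-yl for Thiophen-2-yl on a Second Core

The compounds below may be only part of what the source reports. "The series", "measured", "known", "first", "only" and "open" are said of these compounds alone.

Compound 3 `c1cc(Nc2nccc(-c3cccs3)n2)cc(OCCn2ccnc2)c1` gives 100 nM in a functional assay for inhibition, with Homo sapiens as the target; a higher number here means a weaker inhibitor, a lower number a stronger inhibitor. Compound 1 `c1ccc(-c2ccnc(Nc3cccc(OCCn4ccnc4)c3)n2)nc1` carries the change (pyridin-2-yl in place of thiophen-2-yl on an aromatic carbon), and in this assay compound 1 gives 400 nM, a step of a 4.0-fold higher number from compound 3 to compound 1 (0.60 log units; beyond the scatter). Compound 2 `c1csc(-c2ccnc(Nc3ccc(-n4ccnc4)cc3)n2)c1` gives 4300 nM in this assay; the difference between its core and the core of compound 3 is not broken down here. Compound 4 `c1ccc(-c2ccnc(Nc3ccc(-n4ccnc4)cc3)n2)nc1` is related to compound 2 by the same change, (pyridin-2-yl in place of thiophen-2-yl on an aromatic carbon), made on this other core. For the measured compounds named here, the one measured instance points to a weakening, so for compound 4 the expected step is a 3.5-fold higher number from compound 2 to compound 4 (0.54 log units; beyond the scatter), set beside the earlier one because compound 2 gives 4300 nM and the step of a 4.0-fold higher number from compound 3 to compound 1 (0.60 log units; beyond the scatter) is the only guide. The estimate for compound 4 is 15000 nM, between 5000 nM and 45000 nM.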

Compound 4, half-maximal inhibitory concentration: 1400 nM
The estimate for compound 4 lay 11-fold (1.03 log units) above the measured number; the measured number lies below the stated range.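

On the core of compound 2, pyridin-2-yl in place of thiophen-2-yl gives a 3.1-fold lower number from compound 2 to compound 4 (0.49 log units; beyond the scatter) in this assay, so the change does not keep its direction when carried over from the core of compound 3. The two steps differ, which shows that in this series the outcome of the change depends on the core that carries it: the same change on two cores in this assay, a 4.0-fold higher number (0.60 log units; beyond the scatter) from compound 3 to compound 1 and a 3.1-fold lower number (0.49 log units; beyond the scatter) from compound 2 to compound 4, 12-fold (1.09 log units) apart, beyond the scatter of two such steps

These two pairs do not show which difference between the cores matters, and they give no rule for a third core. From the compounds shown here alone, it remains open whether phenyl or pyridin-3-yl in place of thiophen-2-yl would also follow the core in this way. Going by these compounds, it is equally open how either core would respond to an amine or a carboxylic acid at this same place.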